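This account rests on a few compounds, and the source may have more. Where it says the series, first, only, none or still open, it means among the compounds named here.

Two compounds carry numbers in an assay on HEK293 cells for displacement of a labelled ligand from Urotensin-2 receptor (Homo sapiens), read by fluorescence, with a stated time of 90 min; a lower number here means a stronger inhibitor, a higher number a weaker inhibitor. Compound 1 `O=C(NC1CCN(Cc2ccc(OC3CCNCC3)c(Br)c2)CC1)c1cscn1` gives 970 nM. Compound 2 `O=C(NC1CCN(Cc2ccc(OC3CCNCC3)c(Br)c2)CC1)c1cc2cc(Br)ccc2s1` gives 86 nM, the lower of the two. Within the data shown here, the single measured step, an 11-fold lower number from compound 1 to compound 2 (1.05 log units; beyond the scatter), exchanges the whole group on the carbonyl carbon; it shows that this group moves the number strongly, but it says nothing about a change of substituent within the fused two-ring system once that system is in place. Compound 3 `COc1ccc2sc(C(=O)NC3CCN(Cc4ccc(OC5CCNCC5)c(Br)c4)CC3)cc2c1` keeps the core of compound 2 and carries methoxy in place of bromo on an aromatic carbon. Among the measured compounds shown here, no measured pair exchanges one substituent for another on that fused system, so there is no step to read this change against. Compound 3 is therefore expected to stay close to compound 2, with a step of a 1.3-fold higher number from compound 2 to compound 3 (0.11 log units; within the scatter) that may well fall within the scatter. The estimate for compound 3 in this assay is 110 nM, with a range from 30 nM to 400 nM.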

Compound 3, half-maximal inhibitory concentration: 100 nM
Compound 3: middle estimate off by 1.1-fold (0.04 log units), on the high side, within the range that was stated.
By their numbers in this assay, from the lowest: compounds 2 and 3 (each within the scatter of the next); then compound 1.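

Exchanging bromo for methoxy on this aromatic carbon of the fused system gives, in this assay, a 1.2-fold higher number from compound 2 to compound 3 (0.07 log units; within the scatter), so the two substituents cannot be told apart here. The advantage over the 1,3-thiazol-4-yl group does not rest on bromo alone: 5-methoxy-1-benzothiophen-2-yl gives a 9.7-fold lower number from compound 1 to compound 3 (0.99 log units; beyond the scatter), a step of the same order as an 11-fold lower number from compound 1 to compound 2 (1.05 log units; beyond the scatter). No supporting data bear on why bromo and methoxy read alike at this position.

Still open, from the compounds shown here alone, is how hydrogen, an amine or a carboxylic acid on this same carbon would read against bromo and methoxy. Also open, going by these compounds, is whether a longer chain, such as ethoxy or propoxy, would keep the number of the methoxy compound 3.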